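This account rests on a few compounds, and the source may have more. Where it says the series, first, only, none or still open, it means among the compounds named here.

Measured compounds:
compound 1 `CCCN(CCC)c1nc(C)nc2c1n(C)c(=O)n2-c1ccc(C(C)C)cc1Br` — 7.6 nM
compound 2 `CCCCC(CC)Nc1nc(C)nc2c1n(C)c(=O)n2-c1ccc(C(C)C)cc1Br` — 15.1 nM

In an assay on HEK293 cells for binding affinity to corticotropin-releasing factor receptor 1 (Homo sapiens), read by radioligand binding (on this read-out lower numbers stand for stronger inhibition and higher numbers for weaker inhibition), compound 1 gives 7.6 nM and compound 2 gives 15.1 nM. Compound 2 holds the higher of the two numbers, but the step of a 2.0-fold higher number from compound 1 to compound 2 (0.30 log units; within the scatter) is within the scatter, so the two compounds cannot be ordered. Compound 3 `COCCNc1nc(C)nc2c1n(C)c(=O)n2-c1ccc(C(C)C)cc1Br` differs from compound 2 by 2-methoxyethyl in place of 1-ethylpentyl on a nitrogen on an aromatic ring; read one bond further out, (1-ethylpentyl)amino becomes (2-methoxyethyl)amino. Among the measured compounds shown here, the only measured step, from compound 1 to compound 2, exchanges one branched seven-carbon amine for another and says little about a change to a shorter chain carrying an oxygen. For this reason the expectation for compound 3 rests on the size of the change alone, and a loss in this assay is expected, with the step from compound 2 to compound 3 estimated at a 5.3-fold higher number from compound 2 to compound 3 (0.72 log units; beyond the scatter). Compound 3 is thus expected to give about 80 nM, within a range of 15 nM to 500 nM.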

Compound 3, inhibition constant: 1180 nM
Compound 3: middle estimate off by 15-fold (1.17 log units), on the low side, and the stated range ends below it.
By their numbers in this assay, from the lowest: compounds 1 and 2 (each within the scatter of the next); then compound 3.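

The two earlier compounds, dipropylamino and (1-ethylpentyl)amino, could not be ordered, and on their own they gave no sign that the group on this nitrogen matters much. In this assay the change to 2-methoxyethyl gives a 78-fold higher number from compound 2 to compound 3 (1.89 log units; beyond the scatter) and a 160-fold higher number from compound 1 to compound 3 (2.19 log units; beyond the scatter) for (2-methoxyethyl)amino in place of dipropylamino, so this nitrogen on an aromatic ring is far from indifferent to what it carries. Nothing available accounts for the size of this loss.

The entering group has both fewer heavy atoms and an oxygen, so the compounds shown leave open which of the two differences goes with the loss. A butyl group, which has no oxygen, or a longer ether chain such as 3-methoxypropyl, on the same nitrogen would begin to separate them.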